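This account rests on a few compounds, and the source may have more. Where it says the series, first, only, none or still open, it means among the compounds named here.

Notes on the series. In a functional assay on MCF7 cells (Homo sapiens) for cytotoxicity, read by MTT assay, with a stated time of 48 h (a higher number here means a weaker inhibitor, a lower number a stronger inhibitor), two compounds carry numbers. Compound 1 `C=CC(=C)[C@@H](O)C[C@H]1C(=C)CC[C@@H]2[C@]1(C)CCC[C@]2(C)C(=O)O` reaches only a limit of the assay in this assay, > 40000 nM. Compound 2 `C=CC(=C)CC[C@@H]1[C@@]2(C)CCC[C@](C)(COC(=O)/C=C/c3ccc(O)c(OC)c3)[C@@H]2CC[C@@]1(C)O` gives 13500 nM in this assay. Compound 1 therefore stands at the limit of > 40000 nM in this assay, at which 1 of the 2 values shown sits, and no number placing it on the scale has been obtained. Going by the values given here, no pair of measured compounds differs in a single place, so nothing measured tells what a change of configuration alone does in this assay.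

Compound 3 `C=CC(=C)[C@H](O)C[C@H]1C(=C)CC[C@@H]2[C@]1(C)CCC[C@]2(C)C(=O)O` is the next compound for this assay. It differs from compound 1 as follows: the two compounds have the same atoms and bonds and differ only in configuration as drawn: 1 of 5 stereo elements differ; a stereocentre at a saturated chain carbon is drawn S in compound 1 and R in compound 3. The same atoms and bonds are kept, and only the configuration drawn at one saturated chain carbon is inverted. The step from compound 1 to compound 3 is expected to remain within the scatter, a step that the limit leaves unreadable from compound 1 to compound 3. This expectation rests on compound 1 standing at the limit of > 40000 nM in this assay, at which 1 of the 2 values shown sits, and on the change being one of configuration only. Compound 3 is accordingly expected near 50000 nM, with a range from 20000 nM to 120000 nM, and is more likely than not to return only a limit again.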

Compound 3, half-maximal inhibitory concentration: > 40000 nM
Compound 3 ended at the assay's limit; the forecaster's own chance of this, stated with the estimate: 75%; the middle value lies beyond the limit too.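

In this assay, compound 1 and compound 3 both return only a limit of the assay, so no step can be read between them, and the inversion at the saturated chain carbon yields no size of effect. The compounds shown leave open what this change of configuration alone does in this assay.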